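The source may report more compounds than this note shows. Statements on the series, on what has been measured and on what is new or still open speak of the compounds shown alone.

Compound 1 `Cc1cccc(Cn2c(CN3CCN(C(=O)c4ccc(C(C)C)cc4)CC3)nc3ccccc32)c1` stands highest of the three compounds measured in an assay on isolated protein for inhibition of aldehyde dehydrogenase 1A1 (Homo sapiens), read by spectrophotometry, tested at 10 uM (a higher number here means more inhibition at the concentration tested (going by the name of the read-out), a lower number less inhibition), giving 67.6%. Compound 2 `Cc1ccccc1Cn1c(CN2CCN(C(=O)C3CC3)CC2)nc2ccccc21` gives 29.1% and compound 3 `O=C(C1CC1)N1CCN(Cc2nc3ccccc3n2Cc2cccc(F)c2)CC1` gives 27.2%; the step of a number 1.9 percentage points lower from compound 2 to compound 3 (within the scatter) lies within the scatter. Compound 4 `Cc1cccc(Cn2c(CN3CCN(C(=O)c4ccc(Br)cc4)CC3)nc3ccccc32)c1` differs from compound 1 by bromo in place of isopropyl on an aromatic carbon. Among the measured compounds shown here, the only measured step alters the group on the saturated chain carbon bound to the aromatic nitrogen, not the aryl group on the carbonyl, so no measured step bears directly on this change. Compound 4 keeps the aryl carbonyl that compound 1 carries, so a modest step in this assay is expected, a number 12.6 percentage points lower from compound 1 to compound 4 (beyond the scatter), and the estimate for compound 4 is 55%, between 35% and 75%.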

Compound 4, a percentage reported as inhibition, at one concentration (the size of the read-out at that concentration, not a potency): 25.8%
Compound 4: middle estimate off by 29.2 percentage points, on the high side; measured number outside the range, below it.
By their numbers in this assay, from the lowest: compounds 4, 3 and 2 (each within the scatter of the next); then compound 1.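

Bromo in place of isopropyl on an aromatic carbon, para to a large group, gives a number 41.8 percentage points lower from compound 1 to compound 4 (beyond the scatter) in this assay. This single change shows that the number is sensitive to the group at this carbon, and that the aryl carbonyl alone does not keep it high. Nothing measured here explains the drop. As far as these compounds go, with only isopropyl and bromo compared at this carbon, it stays open whether the higher number is particular to isopropyl. A tert-butyl, methoxy or chloro group there would help settle that.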